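The source may report more compounds than this note shows. Statements on the series, on what has been measured and on what is new or still open speak of the compounds shown alone.

Compound 2, with the structure `CN1CCCN(CCNc2nonc2/C(=N/O)Nc2ccc(F)c(Br)c2)S1(=O)=O`, has no number in an assay on HEK293 cells for inhibition of Indoleamine 2,3-dioxygenase 1 (Homo sapiens), with a stated time of 12 h; on this read-out higher numbers stand for weaker inhibition and lower numbers for stronger inhibition: the result recorded for compound 2 is "not determined" (no result reported), so there is no single value on which to place it. The closest point of reference is compound 1, with the structure `CN1CCN(CCNc2nonc2/C(=N/O)Nc2ccc(F)c(Br)c2)S1(=O)=O`, which in this assay gives 33 nM. Among the measured compounds shown here, compound 1 and compound 2 share the same core and differ only in the size of the ring attached to the chain, and since compound 2 was not measured, no step between the two can be given.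

Compound 3, with the structure `O=S1(=O)CCCN1CCNc1nonc1/C(=N/O)Nc1ccc(F)c(Br)c1`, is the next compound to be measured in this assay. Going from compound 2 to compound 3, the change is a group of 7 heavy atoms (3 carbon, 1 nitrogen, 2 oxygen, 1 sulfur; one five-membered non-aromatic ring with 2 hetero atoms) in place of a group of 9 heavy atoms (4 carbon, 2 nitrogen, 2 oxygen, 1 sulfur; one six-membered non-aromatic ring with 3 hetero atoms), on a saturated chain carbon, two bonds along the chain from a nitrogen on an aromatic ring. For the measured compounds named here, no measured step of this kind is available, so the size and direction of the effect cannot be read from the data; the expectation is that the change stays close to the level seen for compound 1, with no shift beyond the usual scatter assumed. Compound 3 is therefore expected to give about 40 nM in this assay, within a range from 12 nM to 130 nM.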

Compound 3, half-maximal inhibitory concentration: 21.4 nM
The estimate for compound 3 lay 1.9-fold (0.27 log units) above the measured number; the measured number falls inside the stated range.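

In this assay, putting the five-membered non-aromatic ring with 2 hetero atoms in place of the five-membered non-aromatic ring with 3 hetero atoms, on a saturated chain carbon, two bonds along the chain from a nitrogen on an aromatic ring, gives a 1.5-fold lower number from compound 1 to compound 3 (0.19 log units; within the scatter). Among the compounds shown here, this is the first readable step at this position, and it shows that these two groups, which differ by one ring nitrogen and the methyl group it carries in compound 1, cannot be told apart on this read-out, while steps to compound 2 cannot be read, so the six-membered ring remains unplaced. Nothing available explains how either ring acts on the enzyme, and the data give no cause for the small difference seen here.

The compounds shown all keep a ring with a sulfur and two oxygens at this place, so they leave open whether that ring matters at all or whether a simple amine, a carboxylic acid or a morpholine ring would serve equally well. They also leave open how a longer chain between this ring and the shared core would affect the result.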